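This account rests on a few compounds, and the source may have more. Where it says the series, first, only, none or still open, it means among the compounds named here.

Working notes on the series. Compound 1 `CCCNCCCCOc1c(O)cc(O)c2c(=O)cc(-c3ccccc3)oc12` belongs to the set, but in a functional assay on A549 cells (Homo sapiens) for cytotoxicity, read by MTT assay, with a stated time of 48 h (a lower number here means a stronger inhibitor, a higher number a weaker inhibitor), compound 1 gives "not determined" (no result reported), so it gives nothing to compare against. Compound 2 `CCN(CC)CCCOc1cc(O)c2c(=O)cc(-c3ccccc3)oc2c1OC` is therefore the only anchor: in this assay compound 2 gives 1830 nM, and with compound 1 reporting no number, compound 2 stands alone among the values shown, neither strongest nor weakest by any measured comparison.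

Compound 3 `COc1c(OCCCCN2CCCC2)cc(O)c2c(=O)cc(-c3ccccc3)oc12` has not been measured in this assay. Its difference from compound 2 is confined to one place: (pyrrolidin-1-yl)methyl in place of diethylamino on a saturated chain carbon, three bonds along the chain from an oxygen on an aromatic ring The change keeps the same shared core and the same chain to the oxygen on the aromatic ring; what leaves is diethylamino, what enters is (pyrrolidin-1-yl)methyl, one five-membered non-aromatic ring with one hetero atom, and the count of hydrogen-bond donors and acceptors is unchanged.

Among the compounds with values here, with no step between measured compounds to draw on, the expected step from compound 2 to compound 3 in this assay is small and without direction, a 1.0-fold lower number from compound 2 to compound 3 (0.01 log units; within the scatter), not beyond the usual scatter. Compound 3 is accordingly estimated at 1800 nM in this assay, with a range from 700 nM to 4600 nM.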

Compound 3, half-maximal inhibitory concentration: 1530 nM
For compound 3 the middle estimate is 1.2-fold (0.07 log units) above the measured one, within the range that was stated.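

In this assay the series now has its first readable step at this position: a 1.2-fold lower number from compound 2 to compound 3 (0.08 log units; within the scatter). Diethylamino and (pyrrolidin-1-yl)methyl, on a saturated chain carbon, three bonds along the chain from an oxygen on an aromatic ring, therefore give values within the scatter of each other, even though the exchange, also readable as 3-(diethylamino)propyl to 4-(pyrrolidin-1-yl)butyl, brings in one five-membered non-aromatic ring with 1 hetero atom and leaves the hydrogen-bond donor and acceptor counts unchanged. Nothing at hand offers an explanation for this outcome.

Steps involving compound 1 cannot be read, so this single pair is all the series offers on the position, and it cannot separate the effect of the end group from that of the chain. Still open, going by these compounds, is whether a morpholine ring, a piperidine ring, a primary amine or a carboxylic acid at the end of the chain, or a longer chain carrying the same pyrrolidine ring, would give a step beyond the scatter in this assay.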